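This account rests on a few compounds, and the source may have more. Where it says the series, first, only, none or still open, it means among the compounds named here.

In a functional assay on SK-OV-3 cells (Homo sapiens) (on this read-out higher numbers stand for weaker inhibition of growth and lower numbers for stronger inhibition of growth), compound 1 (`O=S(=O)(/C=C/c1ccc(F)cc1F)Cc1ccc(Nc2ncnc3ccccc23)cc1`) gives 69000 nM, while compound 2 (`O=S(=O)(/C=C/c1ccc(C(F)(F)F)cc1F)Cc1ccc(Nc2ncnc3ccc(Br)cc23)cc1`) gives 5000 nM, the lower of the two numbers, with the gap beyond the scatter. Compound 3 (`O=S(=O)(/C=C/c1ccc(F)cc1F)Cc1ccc(Nc2ncnc3ccc(Br)cc23)cc1`) differs from compound 2 in one place: fluoro in place of trifluoromethyl on an aromatic carbon. Going by the values given here, no measured pair shows this change alone. Compound 1, which also carries 2,4-difluorophenyl, stands at 69000 nM, so a modest rise in the number is expected. The expected change is a 1.8-fold higher number from compound 2 to compound 3 (0.26 log units; within the scatter). For compound 3, the estimated value is 9000 nM, with an expected range of 3000 nM to 30000 nM.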

Compound 3, concentration for 50% growth inhibition: 2000 nM
Compound 3: middle estimate off by 4.5-fold (0.65 log units), on the high side, outside the stated range (below it).
By their numbers in this assay, from the lowest: compound 3; then compound 2; then compound 1.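

In this assay, fluoro in place of trifluoromethyl on this aromatic carbon gives a 2.5-fold lower number from compound 2 to compound 3 (0.40 log units; beyond the scatter), so with bromo present the single fluorine is favoured over trifluoromethyl here. Bromo in place of hydrogen gives a 35-fold lower number from compound 1 to compound 3 (1.54 log units; beyond the scatter), the first reading of that change alone and the larger of the two steps. No measured property of these compounds bears on why either step runs as it does.

As far as these compounds go, whether fluoro also beats trifluoromethyl without the bromo remains open. So does how an amine or a methoxy group would stand on this aromatic carbon.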